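The compounds below may be only part of what the source reports. "The series", "measured", "known", "first", "only" and "open" are said of these compounds alone.

Going by the values given here, in a functional assay on the whole organism for inhibition, with Rattus norvegicus as the target, with stated times of 30 s and 5 min (a lower number here means that less compound is needed, a higher number that more compound is needed for the effect), two compounds have numbers so far. Compound 1 (`CCCc1c(OCCCOc2ccc3c(O)c([N+](=O)[O-])c(=O)oc3c2)ccc(C(C)=O)c1O`) gives 4.8 nM while compound 2 (`CCCc1ccccc1OCC(O)COc1ccc2c(O)c([N+](=O)[O-])c(=O)oc2c1`) gives 1.1 nM and so holds the lower of the two numbers, with a gap beyond the scatter of repeat measurements. The two compounds differ in more than one place, so their gap says nothing about any single change.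

Compound 3 (`CCCc1cc(F)ccc1OCC(O)COc1ccc2c(O)c([N+](=O)[O-])c(=O)oc2c1`) keeps all of compound 2 except one spot, with fluoro in place of hydrogen on an aromatic carbon para to a large group and meta to a propyl group. This turns 2-propylphenyl into 4-fluoro-2-propylphenyl. Among the compounds with values here, neither measured compound carries a fluoro, so the data hold no step that shows what this swap does.

A single swap of this kind is a small edit, so no step beyond the scatter is expected in this assay, in either direction. The starting point is compound 2 at 1.1 nM and nothing more. The estimated step (a 1.1-fold higher number from compound 2 to compound 3 (0.04 log units; within the scatter)) is accordingly expected to stay within the scatter. For compound 3 the expected value is 1.2 nM (estimated range 0.4 nM to 3.6 nM).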

Compound 3, concentration for half-maximal effect: 1.7 nM
Beside the measured number, compound 3's estimate is 1.4-fold (0.15 log units) below it; the measured number falls inside the stated range.
By their numbers in this assay, from the lowest: compounds 2 and 3 (each within the scatter of the next); then compound 1.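

In this assay, going by these compounds alone, the swap of hydrogen for fluoro on the aromatic carbon para to a large group and meta to a propyl group, which turns 2-propylphenyl into 4-fluoro-2-propylphenyl, gives a 1.5-fold higher number from compound 2 to compound 3 (0.19 log units; within the scatter), the first single change that can be read. This carbon therefore accepts a fluoro with no change that can be told apart from the ordinary spread of repeat measurements, so compound 2 and compound 3 count as equal here, and the small edit leaves the number where it was. Nothing measured alongside these numbers speaks to why the swap behaves this way.

This single step covers only one small atom at one carbon, so it cannot show whether a chloro, a methoxy or a trifluoromethyl group, or a bulkier or charged group such as an amine, would be accepted on the same carbon. It also leaves open whether a fluoro on another carbon of the same ring, or a change to the propyl group itself, would move the number beyond the scatter.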